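A few compounds are considered here, and "the series" means these few. Any claim that something is new, unique, unknown or untested is made for them only; others in the source may bear on it.

The measured compounds:

Compound 1 `O=c1ccoc2cc(OCc3cn(Cc4ccc(Cl)cc4)nn3)ccc12` — in an ADME assay on L02 cells (Homo sapiens) for cytotoxicity, read by MTT assay, with a stated time of 48 h (on this read-out higher numbers stand for weaker inhibition and lower numbers for stronger inhibition), compound 1 gives > 300000 nM, which is a limit of the assay.
Compound 2 `O=c1ccoc2cc(OCc3cn(Cc4cccc(Cl)c4)nn3)ccc12` — in this assay compound 2 gives > 300000 nM, which is a limit of the assay.
Compound 3 `O=c1ccoc2cc(OCc3cn(Cc4cccc([N+](=O)[O-])c4)nn3)ccc12` — in this assay compound 3 gives > 300000 nM, which is a limit of the assay.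

Compound 3 therefore stands where every measured compound of the set stands: at the limit of > 300000 nM in this assay, at which 3 of the 3 values shown sit, with no number beneath it. Among the measured compounds the steps are a step that the two limits leave unreadable from compound 1 to compound 2, a step that the two limits leave unreadable from compound 1 to compound 3 and a step that the two limits leave unreadable from compound 2 to compound 3, so none of them gives a readable size.

The new compound 4 `N#Cc1cccc(Cn2cc(COc3ccc4c(=O)ccoc4c3)nn2)c1` differs from compound 3 by cyano in place of nitro on an aromatic carbon. Among the compounds with values here, the only measured step that touches the same position, a step that the two limits leave unreadable from compound 2 to compound 3, is unreadable, and the two other steps change the place of the group rather than the group itself; nothing measured separates one substituent on this ring from another. On that basis compound 4 is expected to sit at the assay limit as well, and no step beyond the scatter is expected in this assay.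

The expected step is a step that the limit leaves unreadable from compound 3 to compound 4.

For compound 4 the estimate in this assay is 500000 nM, with a range from 150000 nM to 2000000 nM.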

Compound 4, half-maximal inhibitory concentration: > 300000 nM
Compound 4 ended at the assay's limit; the forecaster's own chance of this, stated with the estimate: 85%; the middle value lies beyond the limit too.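

In this assay compound 4 gives > 300000 nM, which is a limit of the assay. None of the steps to compound 4 from compound 1, compound 2 or compound 3 can be read. The compounds shown leave open how far each lies past that limit and whether any of these substituents separates one compound from another: the limit of > 300000 nM in this assay, at which 4 of the 4 values shown sit.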